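Trifluoromethoxy for trifluoromethyl, carried to a second core

The source may report more compounds than this note shows. Statements on the series, on what has been measured and on what is new or still open speak of the compounds shown alone.

Compound 1 `O=C1/C(=C/c2cccc(C(F)(F)F)c2)CCc2cc(O)ccc21` and compound 2 `O=C1/C(=C/c2cccc(OC(F)(F)F)c2)CCc2cc(O)ccc21` share one core; compound 3 `O=C1/C(=C/c2ccccc2C(F)(F)F)CCc2ccc(O)cc21` and compound 4 `O=C1/C(=C/c2ccccc2OC(F)(F)F)CCc2ccc(O)cc21` share another. How the core of compound 1 and the core of compound 3 differ is not broken down here; their values alone are compared below. In a functional assay on RAW264.7 cells (Mus musculus) for inhibition (a higher number here means a weaker inhibitor, a lower number a stronger inhibitor), compound 1 gives 180 nM, compound 2 gives 520 nM, and compound 3 gives 1020 nM. Among the compounds with values here, the one measured step of the change is a 2.9-fold higher number from compound 1 to compound 2 (0.46 log units; beyond the scatter), the change being (trifluoromethoxy in place of trifluoromethyl on an aromatic carbon). The same kind of change, not the same, is made in the second core: trifluoromethoxy in place of trifluoromethyl on an aromatic carbon, where the entering group sits ortho to a large group rather than meta to a large group. Compound 4 has not been measured in this assay. Within the data shown here, because a 2.9-fold higher number from compound 1 to compound 2 (0.46 log units; beyond the scatter) is the only measure of this change, the expected step is a 2.7-fold higher number from compound 3 to compound 4 (0.44 log units; beyond the scatter), carried over from the first core with wide bounds. Compound 4 is estimated at 2800 nM in this assay, expected to fall between 1300 nM and 6000 nM.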

Compound 4, half-maximal inhibitory concentration: 420 nM
Compound 4: middle estimate off by 6.7-fold (0.82 log units), on the high side; measured number outside the range, below it.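

In this assay, trifluoromethoxy in place of trifluoromethyl gives a 2.4-fold lower number from compound 3 to compound 4 (0.39 log units; beyond the scatter) in the second core, so the change does not keep its direction from one core to the other: the same change on two cores in this assay, a 2.9-fold higher number (0.46 log units; beyond the scatter) from compound 1 to compound 2 and a 2.4-fold lower number (0.39 log units; beyond the scatter) from compound 3 to compound 4, 7.0-fold (0.85 log units) apart, beyond the scatter of two such steps.
Within this series, then, a step measured on one core is no safe guide to the sign of the same change on the other, and two pairs are too few to support any wider rule.
The result does not show whether the reversal belongs to the core or to the place of the entering group, ortho to a large group in compound 4, for the two pairs differ in both and the data do not separate them.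

Open, from the compounds shown here alone, is how this change behaves when the entering group is ortho to a large group on the core of compound 1, which would help to separate those two differences.
Also open, going by these compounds, is whether a nitrile, a methyl group or a chlorine atom on the same aromatic carbon would follow either step.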